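The source may hold more compounds than are shown below. What is called first, only, known or untested is meant among the compounds shown, and "the series" means these compounds.

Working notes on the series. Compound 1 `CC[C@](O)(c1cn(Cc2ccc3c(-c4ccc(F)cc4)c(C(N)=O)sc3c2)nn1)C(F)(F)F` is the stronger of the two measured compounds in an assay on blood for inhibition of Polyunsaturated fatty acid 5-lipoxygenase (Homo sapiens) (on this read-out higher numbers stand for weaker inhibition and lower numbers for stronger inhibition), where compound 1 gives 21 nM. For the measured compounds named here, the only other measured member, compound 2 `CCC(O)(c1cn(Cc2ccc3c(-c4ccccc4)csc3c2)nn1)C(F)(F)F`, lacks the fluorine and the carboxamide of compound 1 and is drawn without a defined configuration at the chain carbon; in this assay compound 2 gives 598 nM, a gap that lies beyond the scatter. Compound 3 `CC[C@@](O)(c1cn(Cc2ccc3c(-c4ccc(F)cc4)c(C(N)=O)sc3c2)nn1)C(F)(F)F` is the next step from compound 1: the two compounds have the same atoms and bonds and differ only in configuration as drawn: 1 of 1 stereo elements differ; a stereocentre at a saturated chain carbon is drawn S in compound 1 and R in compound 3. Nothing is known here about how the two configurations at this carbon compare in this assay; compound 2 gives no guidance on this point, since its stereocentre is undefined. Given that compound 1 is drawn as a single enantiomer and sits at the low end of the numbers, a move to the opposite configuration is expected to raise the number in this assay, with a wide spread of plausible outcomes, so the step from compound 1 to compound 3 is estimated at a 9.5-fold higher number from compound 1 to compound 3 (0.98 log units; beyond the scatter). Compound 3 is therefore expected to give about 200 nM in this assay, within a range of 25 nM to 2000 nM.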

Compound 3, half-maximal inhibitory concentration: 154 nM
For compound 3 the middle estimate is 1.3-fold (0.11 log units) above the measured one, within the range that was stated.
By their numbers in this assay, from the lowest: compound 1; then compound 3; then compound 2.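

In this assay, the saturated chain carbon now has a readable step: going from the S to the R configuration gives a 7.3-fold higher number from compound 1 to compound 3 (0.87 log units; beyond the scatter), so configuration at this carbon by itself moves the number beyond the scatter. The R form still retains measurable inhibition, with compound 3 at 154 nM, so on this pair the S configuration is favoured but is not an absolute requirement. The gap can be assigned to this stereocentre alone, and not to any substituent, because the pair offers no other structural difference: the fact that compounds 1 and 3 differ only in the configuration as drawn.

Compound 2, drawn without a defined configuration at this carbon, cannot show whether the same gap between S and R holds without the fluorine and the carboxamide. Going by these compounds, it also remains open whether the preference for S would survive a longer chain in place of the ethyl group at this carbon, or a carboxylic acid in place of the carboxamide.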